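A few compounds are considered here, and "the series" means these few. Any claim that something is new, unique, unknown or untested is made for them only; others in the source may bear on it.

In a functional assay on HEK293 cells (Homo sapiens) for cytotoxicity (a lower number here means that less compound is tolerated, a higher number that more compound is tolerated), compound 1, `COc1ccc([C@H]2CC(=O)N(C(C)=O)C2)cc1OC1CCCC1`, gives > 10000 nM, which is a limit of the assay and not a number. Compound 2, `COc1ccc([C@H]2CC(=O)N(c3ccc(C)cc3)C2)cc1OC1CCCC1`, gives > 10000 nM, again a limit. Compound 3, `COc1ccc([C@H]2CC(=O)N(c3ccccc3C(F)(F)F)C2)cc1OC1CCCC1`, gives > 10000 nM, also a limit. Compound 3 therefore stands with the other two, at the limit of > 10000 nM in this assay, at which 3 of the 3 values shown sit.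

Compound 4, `COc1ccc([C@H]2CC(=O)N(c3cccc(C(F)(F)F)c3)C2)cc1OC1CCCC1`, has not yet been measured. It differs from compound 3 by 3-(trifluoromethyl)phenyl in place of 2-(trifluoromethyl)phenyl on an amide-type nitrogen in a ring. Three measured steps change the group on that same nitrogen: a step that the two limits leave unreadable from compound 1 to compound 2, a step that the two limits leave unreadable from compound 1 to compound 3 and a step that the two limits leave unreadable from compound 2 to compound 3. None has a readable size, as each joins two limits. Acetyl, 4-methylphenyl and 2-(trifluoromethyl)phenyl all leave the read-out at the limit, so no step beyond the scatter is expected in this assay, in either direction. The expected change is a step that the limit leaves unreadable from compound 3 to compound 4. Compound 4 is estimated at 15000 nM, with an expected range from 6000 nM to 40000 nM.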

Compound 4, half-maximal cytotoxic concentration: > 10000 nM
Compound 4: a limit, no number (the forecaster's own chance of this, stated with the estimate: 90%); the middle value is on the limit's open side.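

Compound 4 gives a limit and not a number, as do compound 1, compound 2 and compound 3, so no step among them can be read in this assay: the limit of > 10000 nM in this assay, at which 4 of the 4 values shown sit.

The compounds shown leave open the concentration at which any of them becomes cytotoxic, and whether changing the group on the ring nitrogen alters it.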